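The source may hold more compounds than are shown below. What is called first, only, known or untested is meant among the compounds shown, and "the series" means these compounds.

Measured compounds:
compound 1 `COc1ccccc1N1CCN(CCCCCCN2C(=O)c3ccccc3S2(=O)=O)CC1`, 105 nM
compound 2 `O=C1c2ccccc2S(=O)(=O)N1CCCCCN1CCN(c2cccc(Cl)c2Cl)CC1`, 149 nM

Of the compounds shown here, two have been measured in an assay on HEK293 cells for displacement of a labelled ligand from 5-hydroxytryptamine receptor 7 (Homo sapiens); on this read-out lower numbers stand for stronger inhibition and higher numbers for weaker inhibition. Compound 1 `COc1ccccc1N1CCN(CCCCCCN2C(=O)c3ccccc3S2(=O)=O)CC1` gives 105 nM in this assay, and compound 2 `O=C1c2ccccc2S(=O)(=O)N1CCCCCN1CCN(c2cccc(Cl)c2Cl)CC1` gives 149 nM. Compound 2 holds the higher of the two numbers, but the gap to compound 1 lies within the scatter of repeated measurements, so the two cannot be told apart on this evidence.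

The next compound, compound 3 `O=C1c2ccccc2S(=O)(=O)N1CCCCCN1CCN(c2ccccc2)CC1`, keeps the whole of compound 2 except for one change: phenyl in place of 2,3-dichlorophenyl on an amine nitrogen in a ring. Going by the values given here, no step between measured compounds of this kind is available, so the effect of removing both chlorines from the aromatic ring on the piperazine nitrogen has to be judged from the two values alone, which sit close together despite different groups at that position. On that basis no step beyond the scatter is expected for compound 3, and the estimated step of a 1.3-fold higher number from compound 2 to compound 3 (0.13 log units; within the scatter) is taken as small. Compound 3 is therefore expected to give about 200 nM in this assay, with a range from 60 nM to 700 nM.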

Compound 3, inhibition constant: 148 nM
The estimate for compound 3 lay 1.4-fold (0.13 log units) above the measured number; the range from low to high includes it.
By their numbers in this assay, from the lowest: compounds 1, 3 and 2 (each within the scatter of the next).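

In this assay, going by these compounds alone, this is the first step in which only one place differs, and with the core and chain of compound 2 held fixed, phenyl in place of 2,3-dichlorophenyl on an amine nitrogen in a ring gives (a 1.0-fold lower number from compound 2 to compound 3 (0.00 log units; within the scatter)). The opening pair could only hint that this position tolerates different groups, as those two compounds differ in more than one place; here the two chlorine atoms are the only difference, and compound 2 and compound 3 cannot be told apart. Nothing at hand explains why the two values match.

The compounds shown leave open whether a hydroxyl group, an amine or a carboxylic acid on this aromatic ring would give a step beyond the scatter, as the two groups compared here are both carbon rings with no hydrogen-bond donors or acceptors. Within the data shown here, they also leave open whether phenyl and 2,3-dichlorophenyl would remain this close on a longer chain, such as the one carried by compound 1.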